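A few compounds are considered here, and "the series" means these few. Any claim that something is new, unique, unknown or untested is made for them only; others in the source may bear on it.

Within the data shown here, in an ADME assay on Vero cells (Chlorocebus sabaeus) for cytotoxicity, read by resazurin assay, with a stated time of 72 h (on this read-out higher numbers stand for weaker inhibition and lower numbers for stronger inhibition), compound 1 `COc1ccc(C(=O)CCN2CCN(c3ccc(C(F)(F)F)cc3)CC2)cc1` gives 135000 nM, while compound 2 `O=C(CCN1CCN(c2ccc(C(F)(F)F)cc2)CC1)c1ccc(C(F)(F)F)cc1` gives 49200 nM, the lower of the two numbers so far. Compound 3 `O=C(CCN1CCN(c2ccc(C(F)(F)F)cc2)CC1)c1ccc(OC(F)(F)F)cc1` keeps the rest of compound 2 and changes one group, with trifluoromethoxy in place of trifluoromethyl on an aromatic carbon, para to a large group: trifluoromethoxy in place of trifluoromethyl on an aromatic carbon. Among the measured compounds shown here, only one measured step bears on this swap. It also exchanges a group on that aromatic carbon, trifluoromethyl in place of methoxy: a 2.7-fold lower number from compound 1 to compound 2 (0.44 log units; beyond the scatter). That step is modest, and it does not test the new group directly, so it gives no firm direction. The expected result in this assay is therefore a 1.0-fold higher number from compound 2 to compound 3 (0.01 log units; within the scatter), with no change expected beyond the scatter. The estimated value for compound 3 is 50000 nM, with an expected range of 22000 nM to 110000 nM.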

Compound 3, half-maximal inhibitory concentration: 64900 nM
Compound 3: middle estimate off by 1.3-fold (0.11 log units), on the low side; the measured number falls inside the stated range.
By their numbers in this assay, from the lowest: compounds 2 and 3 (each within the scatter of the next); then compound 1.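

In this assay, moving to trifluoromethoxy on this aromatic carbon, para to a large group, gives a 1.3-fold higher number from compound 2 to compound 3 (0.12 log units; within the scatter), so the two groups cannot be told apart here. Measured against methoxy, the same group gives a 2.1-fold lower number from compound 1 to compound 3 (0.32 log units; beyond the scatter), a modest step beyond the scatter, so both fluorine-bearing groups now give lower numbers than methoxy, and none of the three compounds goes against this. Nothing measured here gives a reason for these numbers.

The compounds shown leave open how a group of a different kind, such as a nitrile, a chlorine atom or a carboxylic acid, would behave on this aromatic carbon. They also leave open whether the same swap would read alike on the other aromatic ring, which carries its own trifluoromethyl in all three compounds.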